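Weak Growth Inhibitors and a Furan-2-yl Variant

This account rests on a few compounds, and the source may have more. Where it says the series, first, only, none or still open, it means among the compounds named here.

Measured in a functional assay on SNB-19 cells (Homo sapiens) for inhibition, read by MTT assay, with a stated time of 7 days; a lower number here means a stronger inhibitor of growth, a higher number a weaker inhibitor of growth:
Compound 1 `C[Si](C)(C)CCOCn1nnc2c(C(N)=O)ncn2c1=O`: 29900 nM
Compound 2 `COc1ccc(Cn2nnc3c(C(N)=O)ncn3c2=O)cc1`: > 50000 nM

Within the data shown here, compound 1 holds the only actual number in this assay, 29900 nM. Compound 2 reads > 50000 nM, which is a limit of the assay and not a number. Compound 3 `NC(=O)c1ncn2c(=O)n(Cc3ccco3)nnc12` keeps the core of compound 1 and carries furan-2-yl in place of a group without a ring, on a saturated chain carbon bound to an aromatic nitrogen (a group of 5 heavy atoms (4 carbon, 1 oxygen; one five-membered aromatic ring with 1 hetero atom) in place of a group of 7 heavy atoms (5 carbon, 1 oxygen, 1 silicon; no ring), on a saturated chain carbon bound to an aromatic nitrogen). Among the measured compounds shown here, no measured step bears on this change, so the expected step of a 1.3-fold higher number from compound 1 to compound 3 (0.13 log units; within the scatter) is estimated to stay within the scatter. For compound 3 the expected value is 40000 nM, with an estimated range of 15000 nM to 90000 nM.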

Compound 3, concentration for 50% growth inhibition: > 50000 nM
Compound 3 gave a limit, no number; the forecaster's own chance of this, stated with the estimate: 45%; at least 1.2-fold (0.09 log units) between middle value and limit.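

With furan-2-yl in place of the ringless group, on a saturated chain carbon bound to an aromatic nitrogen, this assay shows an at least 1.6-fold higher number from compound 1 to compound 3 (0.22 log units; that floor lies within the scatter). Compound 3 gives > 50000 nM, a limit of the assay and not a number, so only a floor on this step can be read. This five-membered aromatic ring thus ends at the same limit as compound 2: the limit of > 50000 nM in this assay, at which 2 of the 3 values shown sit.

The compounds shown do not separate the effect of adding the ring from that of losing the silicon. As far as these compounds go, what an all-carbon chain or an amine would give at this place remains open.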